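Chain extension on the amide nitrogen of compound 2

This account rests on a few compounds, and the source may have more. Where it says the series, first, only, none or still open, it means among the compounds named here.

Measured so far:
compound 1 `CCCSc1nc(Cl)c2c(n1)N(CCNC(=O)OC(C)(C)C)C(C(=O)N1CCN(C)CC1)N2` gives 59300 nM
compound 2 `CCCSc1nc(Cl)c2c(n1)N(Cc1ccccc1)C(C(=O)Nc1ccccc1)N2` gives 58400 nM
compound 3 `CCCSc1nc(Cl)c2c(n1)N(Cc1ccco1)C(C(=O)N1CCN(C)CC1)N2` gives 53800 nM

These three compounds were tested in a functional assay on MGC-803 cells (Homo sapiens) for antiproliferative activity, read by MTT assay, with a stated time of 72 h; a lower number here means a stronger inhibitor, a higher number a weaker inhibitor. In this assay compound 2 has the second highest of the three numbers; its nearest neighbour is compound 1, and its furthest is compound 3, and both of those gaps lie within the scatter, so the three compounds cannot be ordered. Within the data shown here, the only step between measured compounds that differ in one place is a 1.1-fold lower number from compound 1 to compound 3 (0.04 log units; within the scatter), which is likewise within the scatter.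

The new compound is compound 4 `CCCSc1nc(Cl)c2c(n1)N(Cc1ccccc1)C(C(=O)NCCCc1ccccc1)N2`. It differs from compound 2 in one place: 3-phenylpropyl in place of phenyl on an amide-type nitrogen. Among the measured compounds shown here, no measured step touches the amide-type nitrogen, so nothing in the data speaks directly to this change. For the measured compounds named here, the one step that is known, from compound 1 to compound 3, shows that a change on the saturated chain carbon left this assay unmoved, and the three compounds as a whole sit close together. Compound 4 is therefore expected to show no step beyond the scatter, with a 1.1-fold lower number from compound 2 to compound 4 (0.03 log units; within the scatter) as the estimated shift. Compound 4 is estimated at 55000 nM, expected to fall between 25000 nM and 120000 nM.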

Compound 4, half-maximal inhibitory concentration: 16900 nM
For compound 4 the middle estimate is 3.3-fold (0.51 log units) above the measured one; the measured number lies below the stated range.
By their numbers in this assay, from the lowest: compound 4; then compounds 3, 2 and 1 (each within the scatter of the next).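

In this assay, 3-phenylpropyl in place of phenyl on the amide-type nitrogen gives a 3.5-fold lower number from compound 2 to compound 4 (0.54 log units; beyond the scatter), the only step shown that lies beyond the scatter, so this nitrogen is a place where the assay responds, which the earlier compounds gave no sign of. The two groups share one six-membered aromatic ring of carbon only, no hydrogen-bond donors or acceptors and no net charge, and they differ in that the ring of 3-phenylpropyl is carried on a saturated chain instead of sitting directly on the nitrogen. Nothing available explains why the number falls with this change.

One step cannot separate the effect of having a saturated chain at all from the effect of its length, or show whether the phenyl ring is still needed once the chain is present. Benzyl, 2-phenylethyl and 4-phenylbutyl on the same nitrogen would test the dependence on chain length, while a plain propyl group, or a chain ending in an amine or a carboxylic acid in place of phenyl, would test the part played by the ring.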